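A Third Methoxy on the Aryl Group of Compound 3

This account rests on a few compounds, and the source may have more. Where it says the series, first, only, none or still open, it means among the compounds named here.

Compounds 1, 2 and 3 share one core and differ only in the group carried on a saturated ring carbon. Compound 1 `Cc1cc(O)c(C2=NN(c3ccc(S(N)(=O)=O)cc3)C(c3ccccc3Cl)C2)cc1Cl` bears a 2-chlorophenyl there, compound 2 `Cc1cc(O)c(C2=NN(c3ccc(S(N)(=O)=O)cc3)C(/C=C/c3ccccc3)C2)cc1Cl` a 2-phenylethenyl and compound 3 `COc1ccc(C2CC(c3cc(Cl)c(C)cc3O)=NN2c2ccc(S(N)(=O)=O)cc2)cc1OC` a 3,4-dimethoxyphenyl. In a functional assay on SK-OV-3 cells (Homo sapiens) for antiproliferative activity, with a stated time of 48 h (on this read-out lower numbers stand for stronger inhibition of growth and higher numbers for weaker inhibition of growth), compound 1 gives 3630 nM, compound 2 gives 5520 nM and compound 3 gives 4510 nM. All three steps are modest: a 1.5-fold higher number from compound 1 to compound 2 (0.18 log units; within the scatter), a 1.2-fold higher number from compound 1 to compound 3 (0.09 log units; within the scatter) and a 1.2-fold lower number from compound 2 to compound 3 (0.09 log units; within the scatter). Compound 3 thus stands second highest of the three numbers, within the scatter of both its neighbours. Compound 4 `COc1ccc(C2CC(c3cc(Cl)c(C)cc3O)=NN2c2ccc(S(N)(=O)=O)cc2)c(OC)c1OC` differs from compound 3 by methoxy in place of hydrogen on an aromatic carbon. Among the compounds with values here, no measured step adds a single group to this aryl ring; the three swaps of the whole aryl group all stayed within the scatter, so the step of a 1.0-fold lower number from compound 3 to compound 4 (0.00 log units; within the scatter) is expected to be none beyond the scatter. Compound 4 is therefore estimated at 4500 nM, with a range from 2200 nM to 9000 nM.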

Compound 4, concentration for 50% growth inhibition: 3710 nM
Beside the measured number, compound 4's estimate is 1.2-fold (0.08 log units) above it; low and high end bracket the measured number.
By their numbers in this assay, from the lowest: compounds 1, 4, 3 and 2 (each within the scatter of the next).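

Within the data shown here, the step from 3,4-dimethoxyphenyl to 2,3,4-trimethoxyphenyl is the first here that adds a single group to this aryl ring, and in this assay the added methoxy leaves the read-out within the scatter (a 1.2-fold lower number from compound 3 to compound 4 (0.08 log units; within the scatter)). Among these compounds, the new group also stays within the scatter of the two other groups on the saturated ring carbon (a 1.5-fold lower number from compound 2 to compound 4 (0.17 log units; within the scatter); a 1.0-fold higher number from compound 1 to compound 4 (0.01 log units; within the scatter)), so across compounds 1 to 4 no change at this place has yet moved the number beyond the scatter, and no compound goes against this. Nothing available accounts for this flat result.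

The compounds shown leave open whether an amine or a carboxylic acid on this aromatic carbon would give a step beyond the scatter. They also leave open whether a longer chain, such as butoxy, would do so in place of the methoxy.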